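Fluoro in place of methyl on the outer phenyl ring

This account rests on a few compounds, and the source may have more. Where it says the series, first, only, none or still open, it means among the compounds named here.

Three compounds of the series have numbers in a functional assay on HepG2 cells (Homo sapiens) for antiproliferative activity, read by MTT assay, with a stated time of 24 h; a lower number here means a stronger inhibitor, a higher number a weaker inhibitor. Compound 1 `O=c1[nH]cc(S(=O)(=O)Nc2ccccc2-c2cn(-c3ccccc3)nn2)c(=O)[nH]1` gives 6160 nM in this assay. Compound 2 `Cc1ccc(-n2cc(-c3ccccc3NS(=O)(=O)c3c[nH]c(=O)[nH]c3=O)nn2)cc1` gives 8350 nM in this assay. Compound 3 `O=c1[nH]cc(S(=O)(=O)Nc2ccccc2-c2cn(-c3cccc(F)c3)nn2)c(=O)[nH]1` reaches only the limit of > 20000 nM in this assay, at which 1 of the 3 values shown sits, in this assay, so its value > 20000 nM is a limit and not a number. Among the two numbers, compound 2 has the higher one, but the step of a 1.4-fold higher number from compound 1 to compound 2 (0.13 log units; within the scatter) lies within the scatter, so no order between compound 1 and compound 2 is claimed.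

Compound 4 `O=c1[nH]cc(S(=O)(=O)Nc2ccccc2-c2cn(-c3ccc(F)cc3)nn2)c(=O)[nH]1` has not yet been measured. It differs from compound 2 by fluoro in place of methyl on an aromatic carbon.

Within the data shown here, two measured steps bear on this. Putting fluoro in place of hydrogen on compound 1 gave an at least 3.2-fold higher number from compound 1 to compound 3 (0.51 log units; beyond the scatter), and exchanging 4-methylphenyl for 3-fluorophenyl gave an at least 2.3-fold higher number from compound 2 to compound 3 (0.37 log units; beyond the scatter). In compound 3 the fluoro sits as 3-fluorophenyl, whereas compound 4 carries 4-fluorophenyl, so the comparison is not exact. Still, both fluoro-bearing steps raised the number in this assay beyond the scatter, while methyl against hydrogen changed little.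

Compound 4 is therefore expected to give a higher number than compound 2, a step of about a 1.8-fold higher number from compound 2 to compound 4 (0.25 log units; within the scatter). The estimate for compound 4 in this assay is 15000 nM, expected between 6000 nM and 40000 nM, with a fair chance that only a limit is reported.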

Compound 4, half-maximal inhibitory concentration: > 20000 nM
Compound 4 was reported as a limit; the forecaster's own chance of this, stated with the estimate: 35%; middle value at least 1.3-fold (0.12 log units) away from the limit.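

In this assay, the step of an at least 2.3-fold higher number from compound 2 to compound 4 (0.37 log units; beyond the scatter) and the step of an at least 3.2-fold higher number from compound 1 to compound 4 (0.51 log units; beyond the scatter) both lie beyond the scatter, whereas methyl on the outer phenyl ring gave only a 1.4-fold higher number from compound 1 to compound 2 (0.13 log units; within the scatter), which lies within it. Among these compounds, at this place on the ring, para to a large group, the series therefore separates fluoro from both methyl and hydrogen, a distinction that the earlier compounds did not show for this position. Compound 3 and compound 4 are both reported as limits, so the weaker result with fluoro now appears with both 3-fluorophenyl and 4-fluorophenyl, but the step between these two compounds cannot be read and no order between the two placements can be given: the limit of > 20000 nM in this assay, at which 2 of the 4 values shown sit.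

On these data alone, how far compound 3 and compound 4 lie beyond that limit remains open, and with it the true size of the fluoro steps. Also open, as far as these compounds go, is whether a chloro group, a methoxy group, an amine or a carboxylic acid in the same place on the outer phenyl ring would stay close to compound 1 and compound 2 or follow the two fluoro compounds.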